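This account rests on a few compounds, and the source may have more. Where it says the series, first, only, none or still open, it means among the compounds named here.

Compound 1 `CCCCCCCCCCc1ccc(-c2noc(CCCN3CCCC3)n2)cc1` and compound 2 `CCCCCCCCCCc1ccc(-c2noc(CCCN3CCCCC3)n2)cc1` differ by piperidin-1-yl in place of pyrrolidin-1-yl on a saturated chain carbon, three bonds along the chain from an aromatic carbon. In an assay on HeLa cells for inhibition of sphingosine-1-phosphate transporter SPNS2 (Mus musculus), read by LC-MS, tested at 2 uM (on this read-out higher numbers stand for more inhibition at the one concentration tested (going by the name of the read-out) and lower numbers for less inhibition), compound 1 gives 3% and compound 2 gives 0%, the step being a number 3 percentage points lower from compound 1 to compound 2 (within the scatter). Compound 3 `CCCCCCCCCCc1ccc(-c2noc(CC(O)CN3CCCC3)n2)cc1` carries hydroxy in place of hydrogen on a saturated chain carbon bound to two saturated chain carbons relative to compound 1; in this assay compound 3 gives 21%, with steps of a number 18 percentage points higher from compound 1 to compound 3 (beyond the scatter) and a number 21 percentage points higher from compound 2 to compound 3 (beyond the scatter). Compound 4 `CCCCCCCCCCc1ccc(-c2noc(CC(O)CN3CCCCC3)n2)cc1` is not yet measured and differs from compound 3 by piperidin-1-yl in place of pyrrolidin-1-yl on a saturated chain carbon, two bonds along the chain from an oxygen on a saturated carbon. This is the same kind of change as from compound 1 to compound 2, but not the same: there it sits on a saturated chain carbon, three bonds along the chain from an aromatic carbon, here on a saturated chain carbon, two bonds along the chain from an oxygen on a saturated carbon. In this assay the expected step is a number 3 percentage points lower from compound 3 to compound 4 (within the scatter), kept small because a number 3 percentage points lower from compound 1 to compound 2 (within the scatter) lay within the scatter. Compound 4 is therefore estimated at 18% in this assay.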

Compound 4, a percentage reported as inhibition, at one concentration (the size of the read-out at that concentration, not a potency): 2%
Beside the measured number, compound 4's estimate is 16 percentage points above it; the measured number lies below the stated range.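

In this assay, the exchange of pyrrolidin-1-yl for piperidin-1-yl did not carry over from the core of compound 1 to the hydroxy-bearing core, the new step being a number 19 percentage points lower from compound 3 to compound 4 (beyond the scatter): the same change on two cores in this assay, a number 3 percentage points lower (within the scatter) from compound 1 to compound 2 and a number 19 percentage points lower (beyond the scatter) from compound 3 to compound 4, 16 percentage points apart, beyond the scatter of two such steps

The hydroxy change likewise did not carry over from the pyrrolidin-1-yl compounds to the piperidin-1-yl compounds, the step there being a number 2 percentage points higher from compound 2 to compound 4 (within the scatter): the same change on two cores in this assay, a number 18 percentage points higher (beyond the scatter) from compound 1 to compound 3 and a number 2 percentage points higher (within the scatter) from compound 2 to compound 4, 16 percentage points apart, beyond the scatter of two such steps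

With a number 1 percentage points lower from compound 1 to compound 4 (within the scatter), the two changes together leave no step beyond the scatter, but this rests on a single set of four compounds at one concentration and gives neither a cause nor a rule for other amines.

Still open, as far as these compounds go, is whether the hydroxy step persists with azetidin-1-yl or morpholin-4-yl in place of pyrrolidin-1-yl. Also open, from the compounds shown here alone, is how a carboxylic acid in place of the amine would read.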